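A few compounds are considered here, and "the series" means these few. Any claim that something is new, unique, unknown or untested is made for them only; others in the source may bear on it.

Compound 2 `CS/C(=N\C(=O)c1cc(-c2ccccc2)nc2ccccc12)NC(=O)c1cc(-c2ccccc2)nc2ccccc12` and compound 1 `O=C(/N=C(/NC(=O)c1cc(-c2ccccc2)nc2ccccc12)[Se]Cc1ccccc1)c1cc(-c2ccccc2)nc2ccccc12` share the same core and differ only in the group on the carbon with a double bond to nitrogen. In a functional assay on HepG2 cells (Homo sapiens) for cytotoxicity, read by MTT assay, with a stated time of 72 h (on this read-out lower numbers stand for stronger inhibition of growth and higher numbers for weaker inhibition of growth), compound 2 gives 48200 nM, the lower of the two numbers recorded so far, while compound 1 gives 52400 nM; the step of a 1.1-fold lower number from compound 1 to compound 2 (0.04 log units; within the scatter) lies within the scatter, so the two compounds cannot be placed in any order on this assay.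

Compound 3 `C[Se]/C(=N\C(=O)c1cc(-c2ccccc2)nc2ccccc12)NC(=O)c1cc(-c2ccccc2)nc2ccccc12` differs from compound 2 by a group of 2 heavy atoms (1 carbon, 1 selenium; no ring) in place of a group of 2 heavy atoms (1 carbon, 1 sulfur; no ring), on a carbon with a double bond to nitrogen. Going by the values given here, the one measured step that bears on this change is a 1.1-fold lower number from compound 1 to compound 2 (0.04 log units; within the scatter), where a selenium-bearing group was exchanged for methylsulfanyl at the same carbon and the number barely moved. Compound 3 brings selenium back at that position, but without the aromatic ring that compound 1 carries. Among the compounds with values here, since the only comparison available shows no movement beyond the scatter, no step beyond the scatter is expected here either, and the expected step is a 1.0-fold higher number from compound 2 to compound 3 (0.02 log units; within the scatter). Compound 3 is therefore estimated at 50000 nM, with a range from 25000 nM to 100000 nM.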

Compound 3, concentration for total growth inhibition: 10100 nM
For compound 3 the middle estimate is 5.0-fold (0.69 log units) above the measured one; the measured number lies below the stated range.
By their numbers in this assay, from the lowest: compound 3; then compounds 2 and 1 (each within the scatter of the next).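

Keeping the methyl and exchanging methylsulfanyl for the selenium group of compound 3, on a carbon with a double bond to nitrogen, gives a 4.8-fold lower number from compound 2 to compound 3 (0.68 log units; beyond the scatter) in this assay, so the identity of the atom at this place can move the number beyond the scatter, which the earlier pair could not show. Keeping selenium and placing hydrogen in place of phenyl on a saturated chain carbon bound to a selenium atom gives a 5.2-fold lower number from compound 1 to compound 3 (0.72 log units; beyond the scatter) on the same read-out, so the group carried on selenium also counts, and the close numbers of compound 1 and compound 2 no longer suggest a position indifferent to change. Nothing at hand says why either step occurs.

Compound 1 and compound 3 alone leave open how the number responds to chains of intermediate size on selenium, such as an ethyl or a propyl group. From the compounds shown here alone, it also stays open whether the lower number of compound 3 would hold if an amine or a hydroxyl group stood on that carbon instead of a selenium group.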